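Swapping Acetoxy for Pyridinyl on a Chromene Scaffold

This account rests on a few compounds, and the source may have more. Where it says the series, first, only, none or still open, it means among the compounds named here.

Three compounds share one core. Compound 1 `CC1(C)C=C(n2ccccc2=O)c2ccccc2O1` carries hydrogen at the position in question and gives 5.05 in a functional assay (trachea) with Rattus norvegicus as the target; a lower number here means a less potent compound, a higher number a more potent compound, by a factor of ten per unit of this negative logarithm. Compound 2 `CC1(C)C=C(n2ccccc2=O)c2cc(C(=O)c3ccccc3F)ccc2O1` carries a (2-fluorophenyl)carbonyl there and reaches 6.34 in this assay. Compound 3 `CC(=O)Oc1ccc2c(c1)C(n1ccccc1=O)=CC(C)(C)O2` carries an acetoxy group and gives 4.97, the lowest of the three numbers, although its gap to compound 1 is within the scatter, while compound 2 stands far above it.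

Compound 4 `CC1(C)C=C(n2ccccc2=O)c2cc(-c3ccncc3)ccc2O1` differs from compound 3 in one place: pyridin-4-yl in place of acetoxy on an aromatic carbon

Among the compounds with values here, two measured steps bear on this change. The acetoxy group changed nothing against hydrogen, as a number 0.08 log units lower from compound 1 to compound 3 (within the scatter) shows, whereas an aromatic ring bearing substituent raised potency strongly, seen in a number 1.29 log units higher from compound 1 to compound 2 (beyond the scatter) and, in reverse, in a number 1.37 log units lower from compound 2 to compound 3 (beyond the scatter). A pyridin-4-yl ring is an aromatic ring set in the same position, so an upward step is expected, though perhaps smaller than the carbonyl-linked one; the expected step is a number 0.93 log units higher from compound 3 to compound 4 (beyond the scatter). For compound 4 the estimate is 5.9, within a range from 5.2 to 6.6.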

Compound 4, logarithm of the reciprocal of the active concentration, log(1/C): 6.32
Compound 4: middle estimate off by 0.42 log units, on the low side, and the stated range covers the measured number.
By their numbers in this assay, from the lowest: compounds 3 and 1 (each within the scatter of the next); then compounds 4 and 2 (each within the scatter of the next).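

In this assay, pyridin-4-yl stands well clear of acetoxy (a number 1.35 log units higher from compound 3 to compound 4 (beyond the scatter)) and of hydrogen (a number 1.27 log units higher from compound 1 to compound 4 (beyond the scatter)), so at this position a large gain does not need a carbonyl link: an aromatic ring attached directly to the core also gives one. Against the (2-fluorophenyl)carbonyl group the step is within the scatter (a number 0.02 log units lower from compound 2 to compound 4 (within the scatter)), so this assay does not separate these two quite different ring-bearing groups. Nothing measured here explains why either group outperforms acetoxy.

From the compounds shown here alone, whether the ring nitrogen of pyridin-4-yl matters remains open, and a plain phenyl ring in its place would test that. Also open, going by these compounds, is how this position responds to a group with no ring, such as an amine or a longer alkyl chain.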